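Swapping the Aryl Group on the Saturated Ring Carbon

This account rests on a few compounds, and the source may have more. Where it says the series, first, only, none or still open, it means among the compounds named here.

In a functional assay, tested at 50 ug/mL (on this read-out lower numbers stand for a weaker effect and higher numbers for a stronger effect at the one concentration tested), compound 1 `N#CC1=C(N)OC(c2c[nH]c3ccccc23)=C(C#N)C1c1ccc(Br)cc1` gives 14.2% and compound 2 `Cc1ccc(C2C(C#N)=C(N)OC(c3c[nH]c4ccccc34)=C2C#N)cc1` gives 5.2%. Within the data shown here, the only measured step, a number 9 percentage points lower from compound 1 to compound 2 (within the scatter), does not exceed the scatter, so the two values show no reliable difference. Compound 2 stands at the bottom of the two numbers, but its nearest number, that of compound 1, lies within the scatter, so the two cannot be ranked.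

Compound 3 `N#CC1=C(N)OC(c2c[nH]c3ccccc23)=C(C#N)C1c1ccccc1Cl` differs from compound 2 by 2-chlorophenyl in place of 4-methylphenyl on a saturated ring carbon. Among the measured compounds shown here, no measured step matches this change; the one step known, a number 9 percentage points lower from compound 1 to compound 2 (within the scatter), exchanges a different group and offers no guide beyond showing that a small exchange on this scaffold has not moved the read-out beyond the scatter. Both measured values are low, so the read-out for compound 3 is expected to remain in the same region, with no step beyond the scatter in either direction. Compound 3 is therefore estimated at 9%, within 0% to 25%. The expected step of a number 3.8 percentage points higher from compound 2 to compound 3 (within the scatter) is small.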

Compound 3, a percentage reported as activity, at one concentration (the size of the read-out at that concentration, not a potency): 8.5%
Compound 3: the middle estimate sits 0.5 percentage points above what was measured; the range from low to high includes it.
By their numbers in this assay, from the lowest: compounds 2, 3 and 1 (each within the scatter of the next).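

In this assay, 2-chlorophenyl in place of 4-methylphenyl on the saturated ring carbon gives a number 3.3 percentage points higher from compound 2 to compound 3 (within the scatter), and 2-chlorophenyl in place of 4-bromophenyl at the same carbon gives a number 5.7 percentage points lower from compound 1 to compound 3 (within the scatter). The earlier pair showed only that 4-bromophenyl and 4-methylphenyl could not be told apart here; compound 3 extends this to a chlorine-bearing phenyl group with a different substitution pattern, so all three aryl groups now read alike within the scatter and none of the three compounds can be ranked. No independent measurement on hand accounts for this flat read-out at the position.

The compounds shown leave open whether a phenyl group carrying an amine or a carboxylic acid, or a longer alkyl chain in place of the aryl group, would move the read-out beyond the scatter at this carbon. They also leave open how the read-out responds to a change elsewhere on the shared core, such as replacing the 1H-indol-3-yl group, which all three compounds keep.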